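Compound 2 gives up its (3,4-dichlorophenyl)amino group

The source may report more compounds than this note shows. Statements on the series, on what has been measured and on what is new or still open speak of the compounds shown alone.

Compound 1 (`COc1cc(-c2nn(-c3cccc(NC(=O)Nc4cc(C(F)(F)F)cc(C(F)(F)F)c4)c3)cc2-c2ccncc2)ccc1Cl`) gives 491 nM in a functional assay on ACHN cells (Homo sapiens) for inhibition, read by sulforhodamine B assay, with a stated time of 48 h (on this read-out higher numbers stand for weaker inhibition of growth and lower numbers for stronger inhibition of growth), and so shows a lower number than compound 2 (`COc1cc(-c2nn(-c3cccc(NC(=O)Nc4ccc(Cl)c(Cl)c4)c3)cc2-c2ccncc2)ccc1Cl`) at 1000 nM and compound 3 (`O=C(Nc1cccc(-n2cc(-c3ccncc3)c(-c3ccc(Cl)c(O)c3)n2)c1)Nc1ccc(Cl)c(Cl)c1`) at 1040 nM on the same read-out. Compound 2 stands level with compound 3. Among the measured compounds shown here, the only measured step is a 1.0-fold higher number from compound 2 to compound 3 (0.02 log units; within the scatter) and it concerns a different place in the structure, so it offers little guidance here. Compound 4 (`COc1cc(-c2nn(-c3cccc(NC(=O)c4ccccc4)c3)cc2-c2ccncc2)ccc1Cl`) differs from compound 2 by phenyl in place of (3,4-dichlorophenyl)amino on a carbonyl carbon as phenyl in place of (3,4-dichlorophenyl)amino on a carbonyl carbon. For the measured compounds named here, no measured pair shows this change directly, but compound 1 at 491 nM and compound 2 at 1000 nM differ at that end of the structure. The expected move is toward a higher number, estimated as a 3.0-fold higher number from compound 2 to compound 4 (0.48 log units; beyond the scatter) in this assay with wide uncertainty. Compound 4 is estimated at 3000 nM with a range from 1000 nM to 10000 nM on this read-out.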

Compound 4, concentration for 50% growth inhibition: 754 nM
Compound 4: middle estimate off by 4.0-fold (0.60 log units), on the high side; the measured number lies below the stated range.
By their numbers in this assay, from the lowest: compounds 1, 4, 2 and 3 (each within the scatter of the next, the first and the last beyond it).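

In this assay, phenyl in place of (3,4-dichlorophenyl)amino on the carbonyl carbon gives a 1.3-fold lower number from compound 2 to compound 4 (0.12 log units; within the scatter). This position therefore tolerates losing the nitrogen and both chlorines together, with no change in growth inhibition beyond the scatter. Nothing measured here accounts for this result. The compounds shown leave open whether an aromatic ring is needed on this carbonyl carbon at all. They also do not show how a morpholine or a short alkyl chain such as propyl would read there.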